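Quinoxaline sulfones: amine for dimethoxy swap on the anilino ring

The source may report more compounds than this note shows. Statements on the series, on what has been measured and on what is new or still open speak of the compounds shown alone.

Measured so far:
compound 1, `Nc1ccc(Nc2nc3ccccc3nc2S(=O)(=O)c2ccccc2)cc1`: 12900 nM
compound 2, `COc1cc(Nc2nc3ccccc3nc2S(=O)(=O)c2ccc(C)cc2)cc(OC)c1`: 8060 nM

Both numbers come from a functional assay on A549 cells (Homo sapiens) for cytotoxicity, read by MTT assay, with a stated time of 72 h; a higher number here means a weaker inhibitor, a lower number a stronger inhibitor. Compound 1 gives 12900 nM and compound 2 gives 8060 nM. The gap between compound 2 and compound 1 lies within the usual scatter, so the two cannot be told apart on these figures; neither one can be called the stronger inhibitor.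

The next compound is compound 3, `Cc1ccc(S(=O)(=O)c2nc3ccccc3nc2Nc2ccc(N)cc2)cc1`. It is built from compound 2 by the change (4-aminophenyl in place of 3,5-dimethoxyphenyl on a nitrogen on an aromatic ring), that is, 4-aminophenyl in place of 3,5-dimethoxyphenyl on a nitrogen on an aromatic ring. Compound 1 also carries the 4-aminophenyl, and its value sits close to that of compound 2. For the measured compounds named here, no step of this kind has been measured, so the expectation rests on that neighbour alone. The step of a 1.4-fold higher number from compound 2 to compound 3 (0.14 log units; within the scatter) is expected to be small, toward a somewhat higher number at most, and not beyond the scatter, because compound 1 with the same 4-aminophenyl gives 12900 nM in this assay. Compound 3 is therefore estimated at 11000 nM, with a range from 5000 nM to 25000 nM.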

Compound 3, half-maximal inhibitory concentration: 24600 nM
Compound 3: the middle estimate sits 2.2-fold (0.35 log units) below what was measured; the measured number falls inside the stated range.
By their numbers in this assay, from the lowest: compounds 2, 1 and 3 (each within the scatter of the next, the first and the last beyond it).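

In this assay, the change to 4-aminophenyl in place of 3,5-dimethoxyphenyl on a nitrogen on an aromatic ring now has a step that can be read: a 3.1-fold higher number from compound 2 to compound 3 (0.48 log units; beyond the scatter) with the rest of the structure held constant. For the compounds shown here, this is the first difference that lies beyond the scatter, and it shows that the group on this nitrogen can move the number, though only modestly and in a single pair. The other new step, methyl in place of hydrogen on an aromatic carbon, gives a 1.9-fold higher number from compound 1 to compound 3 (0.28 log units; within the scatter) and does not separate the two compounds; no measurement shown here explains either step.

The pairs shown leave open whether the step at the nitrogen holds when hydrogen replaces the methyl on the aromatic carbon, since 3,5-dimethoxyphenyl appears only with that methyl present. Also open, going by these compounds, is how an unsubstituted phenyl, a 4-methoxyphenyl or a 4-hydroxyphenyl on the same nitrogen would read, and so whether the amine or the two methoxy groups account for the step.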